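Sulfonyl aryl exchange in a benzoxazole sulfonamide series

A few compounds are considered here, and "the series" means these few. Any claim that something is new, unique, unknown or untested is made for them only; others in the source may bear on it.

Compound 1 `Cc1ccc(S(=O)(=O)Nc2ccc(-c3nc4ccccc4o3)cc2)cc1` is examined in an ADME assay on HEK293 cells (Homo sapiens) for cytotoxicity, read by resazurin assay, with a stated time of 48 h (a higher number here means that more compound is tolerated, a lower number that less compound is tolerated), where compound 1 gives 88000 nM, the lowest of the two numbers recorded. Compound 2 `O=S(=O)(Nc1ccc(-c2nc3ccccc3o2)cc1)c1ccc(C(F)(F)F)cc1` gives 94000 nM in this assay. Compound 3 `O=S(=O)(Nc1ccc2oc(-c3ccccc3)nc2c1)c1ccc(Cl)s1` reaches only a limit of the assay, > 100000 nM, and no number. Within the data shown here, the step of a 1.1-fold higher number from compound 1 to compound 2 (0.03 log units; within the scatter) is the one measured comparison in this set; it changes the group on the sulfonyl-bound ring and moves the number by an amount within the scatter. The only line of context beyond that is the limit of > 100000 nM in this assay, at which 1 of the 3 values shown sits.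

Compound 4 `COc1ccc(Cl)cc1S(=O)(=O)Nc1ccc(-c2nc3ccccc3o2)cc1` differs from compound 1 as follows: 5-chloro-2-methoxyphenyl in place of 4-methylphenyl on a sulfonyl sulfur. No measured step exchanges this ring for a differently substituted one, so the expectation rests on the small size of the step from compound 1 to compound 2 and on the narrow span of the numbers shown. Compound 4 is therefore expected to sit close to compound 1, with an expected step of a 1.0-fold lower number from compound 1 to compound 4 (0.02 log units; within the scatter), and its estimated value in this assay is 85000 nM, within a range from 40000 nM to 160000 nM.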

Compound 4, half-maximal cytotoxic concentration: 75000 nM
Beside the measured number, compound 4's estimate is 1.1-fold (0.05 log units) above it; the measured number falls inside the stated range.
By their numbers in this assay, from the lowest: compounds 4, 1 and 2 (each within the scatter of the next). At a limit, above all of these: compound 3.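

In this assay, the sulfonyl-bound ring proves open to more than the exchange of one group: 5-chloro-2-methoxyphenyl in place of 4-methylphenyl, which brings in a chlorine and a hydrogen-bond acceptor, gives a 1.2-fold lower number from compound 1 to compound 4 (0.07 log units; within the scatter). Compound 1, compound 2 and compound 4 thus carry three different rings on the sulfonyl sulfur, and their numbers stand each within the scatter of the next, with no order among them. Compound 3 gives a limit and not a number, and it differs from these compounds in more than one place, so it offers no comparison: the limit of > 100000 nM in this assay, at which 1 of the 4 values shown sits.

Going by these compounds, it remains open whether an amine or a carboxylic acid on this ring would move the number beyond the scatter. On these data alone, it also remains open whether these ring exchanges would read alike on the core of compound 3.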